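Isopropyl for Hydroxymethyl: Expected Kinetic Solubility of Compound 3

A few compounds are considered here, and "the series" means these few. Any claim that something is new, unique, unknown or untested is made for them only; others in the source may bear on it.

Compound 1 `COc1cc(Nc2nccc(N(C)C)n2)ccc1F` gives 160000 nM in a physicochemical assay for solubility, read by nephelometry, measured as kinetic solubility; a lower number here means a less soluble compound, a higher number a more soluble compound.
Compound 2 `COc1cc(Nc2nc(CO)cc(N(C)C)n2)ccc1F` gives > 250000 nM in this assay, which is a limit of the assay and not a number (the limit of > 250000 nM in this assay, at which 1 of the 2 values shown sits).

Compound 2 thus stands only at that limit, without a number of its own. For the measured compounds named here, the single measured step that bears on the next change is an at least 1.5-fold higher number from compound 1 to compound 2 (0.19 log units; that floor lies within the scatter), and its floor lies within the scatter. Compound 3 `COc1cc(Nc2nc(C(C)C)cc(N(C)C)n2)ccc1F` differs from compound 2 by isopropyl in place of hydroxymethyl on an aromatic carbon. The hydroxymethyl that accompanied that step now leaves, so a downward step beyond the scatter is expected, an at least 4.1-fold lower number from compound 2 to compound 3 (0.61 log units; beyond the scatter). Compound 3 is expected to give 60000 nM in this assay, between 15000 nM and 250000 nM.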

Compound 3, solubility: 170000 nM
For compound 3 the middle estimate is 2.8-fold (0.45 log units) below the measured one; the measured number falls inside the stated range.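

In this assay, isopropyl in place of hydrogen on this aromatic carbon gives a 1.1-fold higher number from compound 1 to compound 3 (0.03 log units; within the scatter), so the larger group at this position brings no step beyond the scatter. Isopropyl in place of hydroxymethyl gives an at least 1.4-fold lower number from compound 2 to compound 3 (0.16 log units; that floor lies within the scatter), so the departure of hydroxymethyl brings no step that can be shown beyond the scatter either.

On these data alone, the true size of that second step stays open because compound 2 has only a limit and not a number: the limit of > 250000 nM in this assay, at which 1 of the 3 values shown sits. As far as these compounds go, how an amine or a carboxylic acid on this carbon would read also stays open.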